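Cytotoxicity notes on a chloro-to-methyl swap

The compounds below may be only part of what the source reports. "The series", "measured", "known", "first", "only" and "open" are said of these compounds alone.

Compound 1 `Cc1ccc(-c2cc(NO)c(C(=O)Nc3ccccc3)c(=O)o2)cc1` and compound 2 `CNC(=O)c1c(NO)cc(-c2ccc(Cl)cc2)oc1=O` were both run in an ADME assay on Huh-7 cells (Homo sapiens) for cytotoxicity, read by a luciferase reporter and WST assay, with a stated time of 3 days; a lower number here means that less compound is tolerated, a higher number that more compound is tolerated. Compound 1 gives only a limit of > 20000 nM in this assay. Compound 2 likewise gives only a limit of > 20000 nM there. Compound 2 therefore stands at the ceiling of the numbers shown, where every value here sits (the limit of > 20000 nM in this assay, at which 2 of the 2 values shown sit). Compound 3 `CNC(=O)c1c(NO)cc(-c2ccc(C)cc2)oc1=O` differs from compound 2 by methyl in place of chloro on an aromatic carbon. Among the compounds with values here, no measured step covers this change, so no shift beyond the scatter is expected in this assay, in either direction. Compound 3 is expected near 25000 nM, between 12000 nM and 50000 nM, most likely again only as a limit. The expected step is a step that the limit leaves unreadable from compound 2 to compound 3, nothing beyond the scatter.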

Compound 3, half-maximal cytotoxic concentration: > 20000 nM
Compound 3: a limit, no number (the forecaster's own chance of this, stated with the estimate: 85%); the middle value is on the limit's open side.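

No new step can be read between compound 3 and either compound 1 or compound 2, since all three values are limits and not numbers: the limit of > 20000 nM in this assay, at which 3 of the 3 values shown sit.

The compounds shown leave open whether methyl and chloro differ at all in this assay.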